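Adding one fluoro to a low-toxicity compound

A few compounds are considered here, and "the series" means these few. Any claim that something is new, unique, unknown or untested is made for them only; others in the source may bear on it.

Measured in an ADME assay on Vero cells (Chlorocebus sabaeus) for inhibition; on this read-out lower numbers stand for higher toxicity in this test and higher numbers for lower toxicity in this test:
- compound 1 `O=C1/C(=C/c2cccc(Br)c2)CCC/C1=C\c1cccc(Br)c1`: 35900 nM
- compound 2 `COc1ccc(/C=C2\CCC/C(=C\c3ccccc3)C2=O)cc1`: 291000 nM

Compound 2 holds the higher of these two numbers, so it is the less toxic in this assay. Compound 1 lies below it by more than the usual scatter of repeat measurements.

Compound 3 `COc1ccc(/C=C2\CCC/C(=C\c3ccc(F)cc3)C2=O)cc1` has fluoro in place of hydrogen on an aromatic carbon of compound 2, turning a phenyl into a 4-fluorophenyl (fluoro in place of hydrogen on an aromatic carbon). Going by the values given here, no two measured compounds differ in only one place, so there is no direct precedent for this change. Among the compounds with values here, the sole guide is weak: compound 1, the only measured compound carrying a halogen, gives the lower value 35900 nM, though it differs from compound 2 in more than one place. A modest drop is therefore expected, possibly no larger than the scatter, and the estimated step is a 1.7-fold lower number from compound 2 to compound 3 (0.23 log units; within the scatter). The estimated value for compound 3 is 170000 nM, with an expected range from 60000 nM to 400000 nM.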

Compound 3, half-maximal cytotoxic concentration: 378000 nM
Compound 3: the middle estimate sits 2.2-fold (0.35 log units) below what was measured, within the range that was stated.
By their numbers in this assay, from the lowest: compound 1; then compounds 2 and 3 (each within the scatter of the next).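

Going by these compounds alone, this is the first direct one-place comparison. In this assay, turning the phenyl into a 4-fluorophenyl gives a 1.3-fold higher number from compound 2 to compound 3 (0.11 log units; within the scatter) and so the two compounds cannot be told apart in this test. At this position, on an aromatic carbon para to a large group, a fluoro in place of hydrogen therefore leaves no measurable mark on the read-out, and nothing on hand explains why the swap makes so little difference.

As far as these compounds go, whether this tolerance extends to other groups at the same position, such as an amine, a carboxylic acid or a longer alkyl chain, stays open. Also open, from the compounds shown here alone, is whether fluoro would behave the same way on the other aromatic ring of the shared core.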